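The source may report more compounds than this note shows. Statements on the series, on what has been measured and on what is new or still open speak of the compounds shown alone.

Compound 1 `CCCc1cc(C#N)ccc1/N=c1\c(O)c(O)\c1=N/[C@H](C)C(C)(C)C`: 23100 nM
Compound 2 `COc1cc(C#N)ccc1/N=c1\c(O)c(O)\c1=N/[C@H](C)C(C)(C)C`: 290 nM

In a functional assay for inhibition, with Rattus norvegicus as the target (a higher number here means a weaker inhibitor, a lower number a stronger inhibitor), compound 2, at 290 nM, has the lower of the two numbers and so is the stronger inhibitor. Compound 3 `C[C@@H](/N=c1\c(O)c(O)\c1=N/c1ccc(C#N)cc1O)C(C)(C)C` differs from it in one place: hydrogen in place of methyl on an oxygen on an aromatic ring. In short, methoxy becomes hydroxy. Within the data shown here, only one measured step bears on this change: an 80-fold lower number from compound 1 to compound 2 (1.90 log units; beyond the scatter). That step also involves the methoxy group, and its size shows that this assay can respond strongly to a change there. However, it replaced propyl rather than altering the group on the oxygen, so it gives only a loose guide to size and none to direction. With so little data, a moderate shift toward weaker inhibition is expected, an estimated 2.8-fold higher number from compound 2 to compound 3 (0.44 log units; beyond the scatter). For compound 3 the expected value is 800 nM, with an estimated range from 150 nM to 5000 nM.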

Compound 3, half-maximal inhibitory concentration: 6050 nM
Estimate against measurement, compound 3: 7.6-fold (0.88 log units) below; the measured number lies above the stated range.
By their numbers in this assay, from the lowest: compound 2; then compound 3; then compound 1.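

In this assay the loss of just the methyl from the oxygen is a large change, a 21-fold higher number from compound 2 to compound 3 (1.32 log units; beyond the scatter), so the methyl itself counts for a great deal here. An oxygen on this aromatic carbon is not enough to keep the full gain over propyl: hydroxy in place of propyl gives only a 3.8-fold lower number from compound 1 to compound 3 (0.58 log units; beyond the scatter), a much smaller step than an 80-fold lower number from compound 1 to compound 2 (1.90 log units; beyond the scatter), which methoxy gives. No measurement shown explains why this small change matters so much.

From the compounds shown here alone, it remains open whether a longer chain on the oxygen, such as ethoxy, would match methoxy, or whether an amine at this place would behave more like hydroxy. Going by these compounds, all three compounds also share the rest of their structure, so it is unknown whether the same order would hold with other groups elsewhere.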